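Cyano in place of nitrofuran on the ring nitrogen

The source may hold more compounds than are shown below. What is called first, only, known or untested is meant among the compounds shown, and "the series" means these compounds.

Three compounds of the series have numbers in a physicochemical assay for solubility; on this read-out higher numbers stand for higher solubility and lower numbers for lower solubility. Compound 1 `COc1cc2cc(C(=O)CC3=CC[N+](C)(Cc4ccccc4)CC3)sc2cc1OC` gives 20000 ug/mL. Compound 2 `COC(=O)C[N+]1(C)CCC(CCC(=O)c2cc3cc(OC)c(OC)cc3s2)CC1` gives 60000 ug/mL. Compound 3 `COc1cc2cc(C(=O)CCC3CC[N+](C)(Cc4ccc([N+](=O)[O-])o4)CC3)sc2cc1OC` gives 600 ug/mL, the lowest of the three; its nearest neighbour is compound 1 and its furthest is compound 2, both well beyond the scatter. Compound 1 and compound 3 differ in more than one place, so their two values are noted only side by side.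

Within the data shown here, one measured step bears on the next compound: a 100-fold lower number from compound 2 to compound 3 (2.00 log units; beyond the scatter). It shows that the 5-nitrofuran-2-yl group on the saturated chain carbon bound to the ring nitrogen goes with a large drop against the methoxycarbonyl group at the same place.

Compound 4 `COc1cc2cc(C(=O)CCC3CC[N+](C)(CC#N)CC3)sc2cc1OC` is not yet measured. The change from compound 3 is cyano in place of 5-nitrofuran-2-yl on a saturated chain carbon bound to an amine nitrogen in a ring. Among the measured compounds shown here, this removes the group that the single relevant step tied to the large drop and puts a small group in its place, so a large rise in this assay is expected, of about the size seen in reverse between compound 2 and compound 3, though the cyano group is not the methoxycarbonyl group and the match is loose.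

For compound 4 the expected value is 20000 ug/mL, within 5000 ug/mL to 60000 ug/mL, which means an expected step of a 33-fold higher number from compound 3 to compound 4 (1.52 log units; beyond the scatter).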

Compound 4, solubility: 2000 ug/mL
Compound 4: the middle estimate sits 10-fold (1.00 log units) above what was measured; the measured number lies below the stated range.
By their numbers in this assay, from the lowest: compound 3; then compound 4; then compound 1; then compound 2.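

In this assay, three groups can now be compared on a saturated chain carbon bound to an amine nitrogen in a ring, and cyano in place of 5-nitrofuran-2-yl gives only a 3.3-fold higher number from compound 3 to compound 4 (0.52 log units; beyond the scatter). Taking away the 5-nitrofuran-2-yl group therefore does not by itself recover the high level of the methoxycarbonyl compound, as cyano in place of methoxycarbonyl gives a 30-fold lower number from compound 2 to compound 4 (1.48 log units; beyond the scatter), so the larger part of the gap between compound 2 and compound 3 lies on the methoxycarbonyl side of compound 4. The order at this place is thus 5-nitrofuran-2-yl, then cyano, then methoxycarbonyl, and nothing in hand explains that order.

On these data alone, it remains open whether the high number of compound 2 is particular to methoxycarbonyl or is shared by a carboxylic acid or a primary amide at the same place. Among these compounds, also open is how a longer chain between the ring nitrogen and the cyano or methoxycarbonyl group would stand against these three compounds, since each step so far changes only the group on the single chain carbon.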